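Changing the aromatic ring at the end of the chain

The compounds below may be only part of what the source reports. "The series", "measured", "known", "first", "only" and "open" are said of these compounds alone.

Measured so far:
Compound 1 `C/C(=C\C(=O)Nc1ccc2nc(N3CCC(O)(C4CC4)CC3)nc(C)c2c1)c1ccc(Cl)cc1` gives 340 nM in a functional assay on CHO-K1 cells for antagonist activity at melanin-concentrating hormone receptor 1 (Homo sapiens), read by inositol phosphate accumulation, with stated times of 10 min and 45 min; a lower number here means a stronger inhibitor, a higher number a weaker inhibitor.
Compound 2 `Cc1nc(N2CCC(O)(C3CC3)CC2)nc2ccc(NC(=O)/C=C/c3ccc(Cl)cc3Cl)cc12` gives 575 nM in this assay.

Compound 2 and compound 1 sit within the scatter of each other, as the step of a 1.7-fold higher number from compound 1 to compound 2 (0.23 log units; within the scatter) shows; neither can be called the stronger inhibitor. Compound 3 `Cc1ccc(/C=C/C(=O)Nc2ccc3nc(N4CCC(O)(C5CC5)CC4)nc(C)c3c2)cc1` differs from compound 2 in one place: 4-methylphenyl in place of 2,4-dichlorophenyl on a double-bonded chain carbon bound to a double-bonded chain carbon. Going by the values given here, the only step measured so far, a 1.7-fold higher number from compound 1 to compound 2 (0.23 log units; within the scatter), also exchanged the aromatic ring at the end of the chain and stayed within the scatter, so that step is the one that bears here, and it suggests the ring substituents matter little in this assay. No step beyond the scatter is therefore expected for compound 3, with the step from compound 2 estimated as a 1.1-fold higher number from compound 2 to compound 3 (0.05 log units; within the scatter). Compound 3 is expected to give about 650 nM in this assay, with a likely range from 220 nM to 2000 nM.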

Compound 3, half-maximal inhibitory concentration: 107 nM
For compound 3 the middle estimate is 6.1-fold (0.78 log units) above the measured one, outside the stated range (below it).
By their numbers in this assay, from the lowest: compound 3; then compounds 1 and 2 (each within the scatter of the next).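

Going by these compounds alone, the aromatic ring at the end of the chain does matter in this assay: 4-methylphenyl in place of 2,4-dichlorophenyl gives a 5.4-fold lower number from compound 2 to compound 3 (0.73 log units; beyond the scatter), the first step in this set beyond the scatter. The second exchange, 2-(4-methylphenyl)ethenyl in place of 2-(4-chlorophenyl)prop-1-en-1-yl, gives a 3.2-fold lower number from compound 1 to compound 3 (0.50 log units; beyond the scatter), so compound 3 is the strongest inhibitor of the three, with its steps to both others beyond the scatter. Nothing available here explains these steps.

Each step changes more than one feature at once, so the chlorine atoms, the ring methyl and the chain methyl cannot be judged separately. A 2-(4-chlorophenyl)ethenyl group would link compounds 1, 2 and 3 directly, while 4-methoxyphenyl or 4-aminophenyl would show how far other groups on the ring shift the number.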